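A Furan Ring in Place of Methyl: Cytotoxicity Outlook

A few compounds are considered here, and "the series" means these few. Any claim that something is new, unique, unknown or untested is made for them only; others in the source may bear on it.

Compound 1, `Cc1cccc(C(=O)N2CCCC(C(=O)Nc3ccc(Cl)cc3)C2)c1`: 0%
Compound 2, `O=C(c1ccccc1)c1cccc(NC(=O)C2CCCN(C(=O)c3cc(C(F)(F)F)cc(C(F)(F)F)c3)C2)c1`: 0%

Of the compounds shown here, two have so far been tested in an ADME assay on PC-3 cells (Homo sapiens) for cytotoxicity, read by WST assay, tested at 100 uM; on this read-out lower numbers stand for less inhibition and higher numbers for more inhibition at the one concentration tested (going by the name of the read-out). Compound 1 gives 0% in this assay. Compound 2 gives 0% in this assay. The two read-outs are level at the digits given, so compound 1 stands together with compound 2, the nearest measured neighbour, with no change beyond the usual scatter. Neither shows measurable inhibition of cell growth at the single concentration tested.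

Compound 3, `O=C(Nc1ccc(Cl)cc1)C1CCCN(C(=O)c2cccc(-c3ccco3)c2)C1`, has not yet been measured. It differs from compound 1 in one place: furan-2-yl in place of methyl on an aromatic carbon. The change sits on an aromatic carbon of a six-membered aromatic ring of carbon only, meta to a large group.

For the measured compounds named here, no pair of measured compounds differing in a single place is available, so the size of such a step in this assay cannot be read from the data. The step of no change at the digits printed from compound 1 to compound 3 (within the scatter) is expected to be none beyond the scatter, in no particular direction. Compound 3 is accordingly estimated at 0%, with a range from 0% to 15%.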

Compound 3, a percentage reported as inhibition, at one concentration (the size of the read-out at that concentration, not a potency): 0%
Compound 3: the middle estimate sits on the measured number at the digits printed; the measured number falls inside the stated range.
By their numbers in this assay, from the lowest: compounds 1, 2 and 3 (each within the scatter of the next).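

In this assay, putting furan-2-yl in place of methyl on an aromatic carbon, meta to a large group, gives no change at the digits printed from compound 1 to compound 3 (within the scatter). For the compounds shown here, this is the first comparison here between two compounds that differ in one place, and it shows that this position can carry a five-membered aromatic ring with a hydrogen-bond acceptor, much larger than methyl, with no inhibition appearing at the one concentration tested. The data shown offer no separate measurement that would explain this result.

The compounds shown leave open whether a charged or chain-like group at the same position, such as an aminomethyl group, a carboxylic acid or a longer alkyl chain, would also leave the read-out where compound 1 stands. They also leave open whether furan-2-yl would behave the same way on another aromatic carbon of the ring, since this single step speaks for one group at one position.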